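Carboxy to methoxycarbonyl on the chain of compound 3

A few compounds are considered here, and "the series" means these few. Any claim that something is new, unique, unknown or untested is made for them only; others in the source may bear on it.

The series shares one core carrying a long chain. Compound 1 `C[C@]1(c2ccc(O)cc2)CSc2cc(O)ccc2[C@H]1CCCCCCCCC[S+]([O-])CCCC(F)(F)C(F)(F)F`, compound 2 `C[C@]1(c2ccc(O)cc2)COc2cc(O)ccc2[C@H]1CCCCCCCCC[S+]([O-])CCCC(F)(F)C(F)(F)F` and compound 3 `C[C@]1(c2ccc(O)cc2)CSc2cc(O)ccc2[C@H]1CCCCCCCCC(CCCC(F)(F)C(F)(F)F)C(=O)O` have been measured in a functional assay on the whole organism for antagonist activity, with Mus musculus as the target, at a dose of 10 mg/kg by the oral route; a higher number here means a stronger effect of the compound at the dose given, a lower number a weaker effect. Compound 1 gives 51%, compound 2 gives 66% and compound 3 gives 77%. Compound 3 thus stands highest of the three numbers; its nearest neighbour is compound 2, which lies lower by a margin beyond the usual scatter, and compound 1 lies lower still, again beyond the scatter. Going by the values given here, no pair among the measured compounds differs in one place only, so no single step can be read from them.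

Compound 4 `COC(=O)C(CCCCCCCC[C@@H]1c2ccc(O)cc2SC[C@]1(C)c1ccc(O)cc1)CCCC(F)(F)C(F)(F)F` is not yet measured. It differs from compound 3 in one place: methyl in place of hydrogen on an oxygen next to a carbonyl group, the same difference cut one bond further out reading carboxy to methoxycarbonyl. Nothing in the measured set shows what this change does in this assay, so the expected step is small, in either direction, and not beyond the scatter. The step from compound 3 to compound 4 is estimated at a number 7 percentage points lower from compound 3 to compound 4 (within the scatter). For compound 4 a value of 70% is expected, within 50% to 88%.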

Compound 4, a percentage reported as inhibition, in the whole organism at one dose (the size of the read-out at that dose, not a potency): 40%
Compound 4: the middle estimate sits 30 percentage points above what was measured; the measured number lies below the stated range.
By their numbers in this assay, from the lowest: compound 4; then compound 1; then compound 2; then compound 3.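

Carboxy to methoxycarbonyl on the chain gives, in this assay, a number 37 percentage points lower from compound 3 to compound 4 (beyond the scatter), the first step in the series that can be read at a single place. At this position, methyl in place of hydrogen on the oxygen next to the carbonyl group is therefore not a neutral change, even though it adds only one heavy atom. Nothing measured here bears on the cause of this step.

The compounds shown leave open whether an ethyl ester, a primary amide or a hydroxamic acid at this place would stay near compound 3 at 77% or fall towards compound 4 at 40% in this assay. From the compounds shown here alone, how a longer chain between the shared core and the carboxylic acid would read is also open.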